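From 4-methylphenyl to 2-methylphenyl: What Size of Step?

The source may hold more compounds than are shown below. What is called first, only, known or untested is meant among the compounds shown, and "the series" means these compounds.

Of the compounds shown here, three sharing one core have been measured so far. In a functional assay on HUVEC cells (Homo sapiens) for cytotoxicity (on this read-out higher numbers stand for an effect only at larger amounts of compound and lower numbers for an effect already at smaller amounts), compound 1 `COC1=C(C)C(=O)/C(=C(O)/C=C/c2cccc(OC)c2)C(=O)C1(C)C` gives 1.6 ug/mL. Compound 2 `COC1=C(C)C(=O)/C(=C(O)/C=C/c2ccc(F)cc2)C(=O)C1(C)C` gives 2 ug/mL, and compound 3 `COC1=C(C)C(=O)/C(=C(O)/C=C/c2ccc(C)cc2)C(=O)C1(C)C` gives 2.4 ug/mL. These numbers all lie within the usual scatter of one another, so compound 3 cannot be ranked against the other two.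

Compound 4 `COC1=C(C)C(=O)/C(=C(O)/C=C/c2ccccc2C)C(=O)C1(C)C` has 2-methylphenyl in place of 4-methylphenyl on a double-bonded chain carbon bound to a double-bonded chain carbon. Earlier swaps at that same place gave a 1.3-fold higher number from compound 1 to compound 2 (0.10 log units; within the scatter) and a 1.5-fold higher number from compound 1 to compound 3 (0.18 log units; within the scatter). Methyl in place of fluoro on an aromatic carbon gave a 1.2-fold higher number from compound 2 to compound 3 (0.08 log units; within the scatter). Going by the values given here, all three steps stayed within the scatter, although none of the measured compounds carries 2-methylphenyl, so this group remains untested.

No step beyond the scatter is therefore expected in this assay, and the estimated change is a 1.2-fold lower number from compound 3 to compound 4 (0.08 log units; within the scatter). The estimate for compound 4 is 2 ug/mL, with an expected range from 1.2 ug/mL to 3.5 ug/mL.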

Compound 4, concentration for half-maximal effect: 2.3 ug/mL
For compound 4 the middle estimate is 1.2-fold (0.06 log units) below the measured one, and the stated range covers the measured number.
By their numbers in this assay, from the lowest: compounds 1, 2, 4 and 3 (each within the scatter of the next).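

Putting 2-methylphenyl in place of 4-methylphenyl only shifts the methyl group on the aromatic ring, and this gives a 1.0-fold lower number from compound 3 to compound 4 (0.02 log units; within the scatter) in this assay, so within these two compounds the shift shows no effect beyond the scatter. The new group also stays within the scatter of the other two groups at this place, with a 1.2-fold higher number from compound 2 to compound 4 (0.06 log units; within the scatter) and a 1.4-fold higher number from compound 1 to compound 4 (0.16 log units; within the scatter), which means that none of the four compounds stands apart from the others. Nothing available explains why these groups give such similar numbers.

As far as these compounds go, all four groups at this place are aromatic rings of carbon only, so it remains open whether an amine, a carboxylic acid or a longer chain there would give a step beyond the scatter. From the compounds shown here alone, all four compounds also share one core, so the effect of changing the core remains open too.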